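A few compounds are considered here, and "the series" means these few. Any claim that something is new, unique, unknown or untested is made for them only; others in the source may bear on it.

Measured so far in a functional assay on NIH3T3 cells (Mus musculus); on this read-out lower numbers stand for an effect already at smaller amounts and higher numbers for an effect only at larger amounts of compound:
- compound 1 `N#Cc1ccc(Cn2cncc2CNc2ccc(C(=O)Nc3cccc([N+](=O)[O-])c3)c(-c3ccccc3)c2)cc1`: > 10 uM
- compound 2 `COC(=O)[C@H](CCSC)NC(=O)c1ccc(NCc2cncn2Cc2cccc(C#N)c2)cc1-c1ccccc1`: > 10 uM
- compound 3 `CSCC[C@H](NC(=O)c1ccc(NCc2cncn2Cc2cccc(C#N)c2)cc1-c1ccccc1)C(=O)O`: > 10 uM

Compound 2 stands at a limit of this assay: its value > 10 uM is a limit, not a number. Compound 1 likewise gives only a limit, > 10 uM. Compound 3 also gives only a limit, > 10 uM. For the measured compounds named here, the one change between measured neighbours, a step that the two limits leave unreadable from compound 2 to compound 3, is hydrogen in place of methyl on an oxygen next to a carbonyl group, and its size cannot be read, since (the limit of > 10 uM in this assay, at which 3 of the 3 values shown sit).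

The next compound is compound 4 `COC(=O)[C@H](CCSC)NC(=O)c1ccc(NCc2cncn2Cc2ccc([N+](=O)[O-])cc2)cc1-c1ccccc1`. It differs from compound 2 by 4-nitrophenyl in place of 3-cyanophenyl on a saturated chain carbon bound to an aromatic nitrogen. Going by the values given here, no measured step speaks readably to this change; the only evidence is that every value of the series sits at the limit (the limit of > 10 uM in this assay, at which 3 of the 3 values shown sit). Compound 4 is therefore expected to sit at that limit too, with the step from compound 2 to compound 4 estimated as a step that the limit leaves unreadable from compound 2 to compound 4. For compound 4 the estimate in this assay is 20 uM, with a range from 5 uM to 80 uM.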

Compound 4, concentration for half-maximal effect: > 10 uM
Compound 4: only a limit was reported (the forecaster's own chance of this, stated with the estimate: 80%); the middle value lies beyond the limit too.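

No step can be read from compound 2 to compound 4 in this assay, since both values are limits: the limit of > 10 uM in this assay, at which 4 of the 4 values shown sit.

The compounds shown leave open how far each one lies past that limit, and whether any change to the shared core would give a readable value in this assay.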